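The source may hold more compounds than are shown below. What is called first, only, known or untested is meant among the compounds shown, and "the series" means these compounds.

Measured in a physicochemical assay for lipophilicity, using the shake flask method, in phosphate buffer, measured as octanol-water partition, with a stated time of 30 min, at pH 7.4; a higher number here means a more lipophilic compound, a lower number a more polar compound:
- compound 1 `Cc1nc(CN(C)C)ccc1-c1cnc(NCc2c(F)ccc3c2CCO3)c2cn[nH]c(=O)c12`: 2
- compound 2 `Cc1cc(-c2cnc(NCc3c(F)ccc4c3CCO4)c3cn[nH]c(=O)c23)n(C)n1`: 3

Compound 2, at 3, stands above compound 1, at 2, and is the higher of the two measured compounds. Compound 3 `CNC(=O)c1ncc(-c2cnc(NCc3c(F)ccc4c3CCO4)c3cn[nH]c(=O)c23)n1C` has not yet been measured. It differs from compound 2 as follows: 1-methyl-2-(methylcarbamoyl)-1H-imidazol-5-yl in place of 1,3-dimethyl-1H-pyrazol-5-yl on an aromatic carbon. In words, 1-methyl-2-(methylcarbamoyl)-1H-imidazol-5-yl stands in place of 1,3-dimethyl-1H-pyrazol-5-yl on an aromatic carbon. Among the measured compounds shown here, one measured step bears on this, a change on the same aromatic carbon: a number 1.00 log units higher from compound 1 to compound 2 (beyond the scatter). For the measured compounds named here, it is a single step with a different group pair, so it shows only that a change at this carbon can move the number beyond the scatter. With the methylcarbamoyl group entering, a downward move of somewhat smaller size is expected in this assay: a number 0.60 log units lower from compound 2 to compound 3 (beyond the scatter). The expected value for compound 3 is 2.4, with an estimated range of 1.8 to 3.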

Compound 3, distribution coefficient: 2.5
For compound 3 the middle estimate is 0.10 log units below the measured one; measured number inside the range.
By their numbers in this assay, from the lowest: compound 1; then compound 3; then compound 2.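

Notes on the aromatic carbon of the shared core: in this assay, 1-methyl-2-(methylcarbamoyl)-1H-imidazol-5-yl in place of 1,3-dimethyl-1H-pyrazol-5-yl gives a number 0.50 log units lower from compound 2 to compound 3 (beyond the scatter) as its step. Relative to 6-((dimethylamino)methyl)-2-methylpyridin-3-yl, the same group gives a number 0.50 log units higher from compound 1 to compound 3 (beyond the scatter) as its step, which places compound 3 between the other two, with all three separated beyond the scatter. Compound 2 and compound 3 both carry a five-membered aromatic ring with 2 hetero atoms, so that ring count alone does not fix the number at this carbon.

No measurement at hand accounts for the size of these steps. Still open, on these data alone, is how the number would respond to a carboxylic acid or a primary amine in place of the methylcarbamoyl group, or to a longer chain on its amide nitrogen.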